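This account rests on a few compounds, and the source may have more. Where it says the series, first, only, none or still open, it means among the compounds named here.

Values in a functional assay on HCT-8 cells (Homo sapiens) for antiproliferative activity, read by sulforhodamine B assay, with a stated time of 3 days (a higher number here means that more compound is needed for the effect, a lower number that less compound is needed), are as follows
- compound 1 `CCCC1=C(OC)C(CCC)(CCC)C(=O)/C(=C(O)\C=C\c2ccccc2)C1=O` gives 3.5 uM
- compound 2 `CCCC1=C(OCC(C)C)C(CCC)(CCC)C(=O)/C(=C(O)\C=C\c2ccccc2)C1=O` gives 8 uM
- compound 3 `CCCC1=C(OCC)C(CCC)(CCC)C(=O)/C(=C(O)\C=C\c2ccccc2)C1=O` gives 5.6 uM

Compound 3 sits within the scatter of both other compounds, as a 1.4-fold lower number from compound 2 to compound 3 (0.15 log units; within the scatter) shows for one of them. Compound 4 `CCCOC1=C(CCC)C(=O)/C(=C(O)/C=C/c2ccccc2)C(=O)C1(CCC)CCC` changes its ethoxy to propoxy, and the counted difference is methyl in place of hydrogen on a saturated chain carbon, two bonds along the chain from an oxygen on an unsaturated carbon in the chain. Two measured steps also add to this chain. A methyl gave a 1.6-fold higher number from compound 1 to compound 3 (0.20 log units; within the scatter) and so stayed within the scatter, while an isopropyl gave a 2.3-fold higher number from compound 1 to compound 2 (0.36 log units; beyond the scatter) and went modestly beyond it. From these two, the expected step is a 1.2-fold higher number from compound 3 to compound 4 (0.06 log units; within the scatter) and so a small upward one inside the scatter of this assay as well. For compound 4 the estimated value is 6.5 uM (expected range 3.5 uM to 12 uM).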

Compound 4, concentration for half-maximal effect: 2.6 uM
Compound 4: middle estimate off by 2.5-fold (0.40 log units), on the high side; the whole stated range lies above it.
By their numbers in this assay, from the lowest: compounds 4, 1, 3 and 2 (each within the scatter of the next, the first and the last beyond it).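

In this assay the change from ethoxy to propoxy gives a 2.2-fold lower number from compound 3 to compound 4 (0.33 log units; beyond the scatter) and so shows that lengthening this chain does not steadily raise the number, while a 1.3-fold lower number from compound 1 to compound 4 (0.13 log units; within the scatter) leaves propoxy and methoxy level. Taking the methyl away from the branched chain gives a 3.1-fold lower number from compound 2 to compound 4 (0.49 log units; beyond the scatter) and places compound 4 clearly apart from compound 2. The same change also reads alike on two cores: the same change on two cores in this assay, a 1.6-fold higher number (0.20 log units; within the scatter) from compound 1 to compound 3 and a 3.1-fold higher number (0.49 log units; beyond the scatter) from compound 4 to compound 2, 1.9-fold (0.28 log units) apart, within the scatter of two such steps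

Going by these compounds, whether butoxy would follow propoxy remains open. So does the effect of a carboxylic acid or an amine on this chain.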